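Extending the Oxanyl Group on Compound 2

This account rests on a few compounds, and the source may have more. Where it says the series, first, only, none or still open, it means among the compounds named here.

Measured in a physicochemical assay for solubility, in phosphate buffer, at pH 7.4; a lower number here means a less soluble compound, a higher number a more soluble compound:
Compound 1 `CC(C)n1cc(-c2ccnc3[nH]c(C4CCN(Cc5cccs5)CC4)cc23)ccc1=O`: 25000 nM
Compound 2 `CN(C)C(=O)CN1CCC(c2cc3c(-c4ccc(=O)n(C5CCOCC5)c4)ccnc3[nH]2)CC1`: 840000 nM

Of these two compounds, compound 2 stands higher, at 840000 nM, and its gap to compound 1 lies beyond the scatter. Compound 3 `CN(C)C(=O)CN1CCC(c2cc3c(-c4ccc(=O)n(CCC5CCOCC5)c4)ccnc3[nH]2)CC1` keeps the rest of compound 2 and carries 2-(oxan-4-yl)ethyl in place of oxan-4-yl on an aromatic nitrogen. Among the measured compounds shown here, the two measured compounds differ in more than one place, so no measured step isolates this change, and the expectation is a judgement with little support from the data. A modest fall in this assay, close to the scatter, is expected. The estimated step is a 1.9-fold lower number from compound 2 to compound 3 (0.27 log units; within the scatter). For compound 3 the estimated value is 450000 nM, with an expected range from 150000 nM to 1000000 nM.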

Compound 3, solubility: 370000 nM
Beside the measured number, compound 3's estimate is 1.2-fold (0.09 log units) above it; the measured number falls inside the stated range.
By their numbers in this assay, from the lowest: compound 1; then compound 3; then compound 2.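

Among the compounds shown here, until this pair, no two measured compounds isolated a change at this position, and in this assay the extension gives a 2.3-fold lower number from compound 2 to compound 3 (0.36 log units; beyond the scatter). The step is modest but lies beyond the scatter, so the number responds to what sits on this aromatic nitrogen, even though 2-(oxan-4-yl)ethyl keeps the six-membered non-aromatic ring and the single hydrogen-bond acceptor of oxan-4-yl and differs in its heavy-atom count. The data shown offer nothing that accounts for this step.

For the compounds shown here, only two groups at this position can be compared here, so a single step cannot show whether the number would keep falling with a longer chain, or how oxan-4-ylmethyl or a chain ending in an amine or a carboxylic acid would compare. As far as these compounds go, it also remains open whether the step would keep its size if the rest of compound 2 were replaced by the rest of compound 1.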